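Benzamide series: halogen on the benzoyl ring

This account rests on a few compounds, and the source may have more. Where it says the series, first, only, none or still open, it means among the compounds named here.

Measured so far:
compound 1 `O=C(NCc1ccc(CNS(=O)(=O)c2ccccc2)cc1)c1ccc(F)cc1` — 40%
compound 2 `O=C(NCc1ccc(CNS(=O)(=O)c2ccccc2)cc1)c1ccccc1` — 62%

In a functional assay on the whole organism for inhibition, with Mus musculus as the target, with stated times of 30 min and 2 h, at a dose of 10 mg/kg by the intraperitoneal route (a lower number here means less inhibition, a higher number more inhibition at the dose given (going by the name of the read-out)), compound 2 stands highest of the two numbers measured; its nearest neighbour, compound 1, sits a number 22 percentage points higher from compound 1 to compound 2 (beyond the scatter) below it. Among the measured compounds shown here, that single step, hydrogen in place of fluoro on an aromatic carbon, is the only comparison the series offers, and it is modest but beyond the scatter.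

Compound 3 `O=C(NCc1ccc(CNS(=O)(=O)c2ccccc2)cc1)c1ccccc1Cl` has not been measured. It differs from compound 2 by chloro in place of hydrogen on an aromatic carbon. For the measured compounds named here, the one measured step bears on it only loosely: it concerns a different halogen at a different place on the same ring, where taking a halogen away raised the number. Placing a halogen back on that ring, this time ortho to a large group, is therefore expected to cost something rather than gain, though the size cannot be read directly from one step.

Compound 3 is estimated at 48%, within 28% to 68%. The expected step is a number 14 percentage points lower from compound 2 to compound 3 (beyond the scatter), a modest fall that a single further measurement could still place within the scatter.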

Compound 3, a percentage reported as inhibition, in the whole organism at one dose (the size of the read-out at that dose, not a potency): "not active" (no number reported)
Compound 3 has no reported number here; there is nothing to compare the estimate with.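

Among the compounds shown here, compound 3 is reported as "not active" in this assay, without a number, so no step from compound 2 to compound 3 can be read. The compounds shown leave open how large a change the 2-chlorophenyl group brings relative to the phenyl of compound 2. No other data bearing on this result are available.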